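Compound 3 to compound 4: bromo in place of fluoro

This account rests on a few compounds, and the source may have more. Where it says the series, first, only, none or still open, it means among the compounds named here.

In a functional assay on HCT-116 cells (Homo sapiens) for cytotoxicity, read by MTT assay, with a stated time of 72 h (a higher number here means a weaker inhibitor, a lower number a stronger inhibitor), compound 1 (`CC(=C\c1ccccc1)/C=C1\CCC=CC1=O`) gives 4800 nM. Compound 2 (`O=C1C=CCC/C1=C\C(Br)=C\c1ccccc1`) reads > 10000 nM, which is a limit of the assay and not a number. Compound 3 (`O=C1C=CCC/C1=C\C=C\c1ccc(F)cc1`) has the lowest of the numeric values at 2200 nM, and its gap to compound 1 lies beyond the scatter.

Compound 4 (`O=C1C=CCC/C1=C\C=C\c1ccc(Br)cc1`) differs from compound 3 as follows: bromo in place of fluoro on an aromatic carbon. This places bromo in place of fluoro on an aromatic carbon. Among the compounds with values here, only one measured step brings in bromo: an at least 2.0-fold higher number from compound 1 to compound 2 (0.31 log units; beyond the scatter). That step replaces methyl on a double-bonded chain carbon, not a group on the aromatic ring, and it ends at the limit of > 10000 nM in this assay, at which 1 of the 3 values shown sits. It therefore bears only weakly on the present change, and gives a direction more than a size. Within the data shown here, no measured step changes a group on the aromatic ring. The expected step is small and within the scatter, at a 1.3-fold higher number from compound 3 to compound 4 (0.10 log units; within the scatter). Compound 4 is estimated at 2800 nM, with an expected range of 1000 nM to 7000 nM.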

Compound 4, half-maximal inhibitory concentration: 5200 nM
Compound 4: middle estimate off by 1.9-fold (0.27 log units), on the low side, within the range that was stated.
By their numbers in this assay, from the lowest: compound 3; then compounds 1 and 4 (each within the scatter of the next). At a limit, above all of these: compound 2.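

In this assay, within the data shown here, the aromatic carbon para to a large group is the first ring position with a measured change, and it responds to the exchange of one halogen for another, with a 2.4-fold higher number from compound 3 to compound 4 (0.37 log units; beyond the scatter). Across the two steps that bring in bromo, the higher number now appears at an aromatic carbon as well as at a double-bonded chain carbon, and neither step goes against this direction. Nothing shown here gives a cause for the step from fluoro to bromo.

The compounds shown leave open how chloro, which would complete the comparison of halogens, would read on this aromatic carbon, and how the same carbon would read with only hydrogen. They also leave open whether an amine, a methoxy group or a carboxylic acid at this place would give a lower or a higher number than fluoro.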